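A few compounds are considered here, and "the series" means these few. Any claim that something is new, unique, unknown or untested is made for them only; others in the source may bear on it.

Compound 1 `O=C1O/C(=C\Cn2cc(-c3cc(F)cc(F)c3)nn2)C(OCc2ccccc2)=C1OCc1ccccc1` in a functional assay on SW-620 cells (Homo sapiens) for antiproliferative activity, read by MTT assay, with a stated time of 72 h (a higher number here means a weaker inhibitor, a lower number a stronger inhibitor), gives only a limit, > 100000 nM.
Compound 2 `COc1ccc(-c2cn(C/C=C3\OC(=O)C(OCc4ccccc4)=C3OCc3ccccc3)nn2)cc1` in this assay likewise gives only a limit, > 100000 nM.
Compound 3 `CCCCCCCCCCc1cn(C[C@H](O)[C@H]2OC(=O)C(OCc3ccccc3)=C2OCc2ccccc2)nn1` in this assay gives 45200 nM.

Compound 3 thus stands as the only one of the three with a number in this assay; the other two sit at the limit of > 100000 nM in this assay, at which 2 of the 3 values shown sit. For the measured compounds named here, the one measured step, a step that the two limits leave unreadable from compound 1 to compound 2, runs between two limits and cannot be read, so it says nothing about the size of any change. Compound 4 `Cc1ccc(S(=O)(=O)NCc2cn(C[C@H](O)[C@H]3OC(=O)C(OCc4ccccc4)=C3OCc3ccccc3)nn2)cc1` differs from compound 3 by ((4-methylphenyl)sulfonyl)amino in place of nonyl on a saturated chain carbon bound to an aromatic carbon. Going by the values given here, no measured step touches a change of this kind, and the expectation for compound 4 rests only on the weak position of compound 3 in this assay. Compound 4 is therefore estimated at 80000 nM, with a range from 30000 nM to 200000 nM, and with a real chance that only a limit is reported. The step of a 1.8-fold higher number from compound 3 to compound 4 (0.25 log units; within the scatter) is expected to be small, with compound 4 landing near compound 3 or toward the weaker side.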

Compound 4, half-maximal inhibitory concentration: 45800 nM
Compound 4: the middle estimate sits 1.7-fold (0.24 log units) above what was measured, within the range that was stated.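

In this assay, for the compounds shown here, the exchange gives a 1.0-fold higher number from compound 3 to compound 4 (0.01 log units; within the scatter), the first step in this set that can be read. At this place, on a saturated chain carbon bound to an aromatic carbon, a plain nonyl chain and ((4-methylphenyl)sulfonyl)amino, which brings a six-membered aromatic ring of carbon only and a hydrogen-bond donor and acceptors, give readings that cannot be told apart. The step from compound 1 to compound 2 still cannot be read, as both values are limits: the limit of > 100000 nM in this assay, at which 2 of the 4 values shown sit.

Compounds 1 and 2 differ from compound 3 and compound 4 in more than one place, leaving open what separates the limits from the numbers. Also open, from the compounds shown here alone, is whether an amine, a carboxylic acid or a short chain such as methyl at this place would give a different reading.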